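This account rests on a few compounds, and the source may have more. Where it says the series, first, only, none or still open, it means among the compounds named here.

In a functional assay on SK-MEL-28 cells (Homo sapiens) for cytotoxicity, read by CCK-8 assay, with a stated time of 24 h (on this read-out lower numbers stand for stronger inhibition and higher numbers for weaker inhibition), compound 1 `COc1ccccc1Oc1c(N)nc(-c2ccccc2)nc1OCCO` gives > 80000 nM, which is a limit of the assay and not a number. Among the compounds with values here, compound 2 `COc1ccccc1Oc1c(N)nc(-c2cccc(F)c2)nc1OCCO` gives 3210 nM, the only actual number so far. Within the data shown here, the one measured step is large: an at least 24-fold lower number from compound 1 to compound 2 (1.39 log units; beyond the scatter). Compound 3 `COc1ccccc1Oc1c(N)nc(-c2cccc(Br)c2)nc1OCCO` differs from compound 2 by bromo in place of fluoro on an aromatic carbon. That single step involved hydrogen rather than bromo, so it offers only weak guidance, and a much smaller, slightly downward change is expected here. The expected step is a 1.5-fold lower number from compound 2 to compound 3 (0.16 log units; within the scatter). Compound 3 is estimated at 2200 nM, within a range of 600 nM to 8000 nM.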

Compound 3, half-maximal inhibitory concentration: 4040 nM
Beside the measured number, compound 3's estimate is 1.8-fold (0.26 log units) below it; low and high end bracket the measured number.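

In this assay, the change from 3-fluorophenyl to 3-bromophenyl gives a 1.3-fold higher number from compound 2 to compound 3 (0.10 log units; within the scatter) and so does not separate these two halogens at this position. Bromo in place of hydrogen gives an at least 19-fold lower number from compound 1 to compound 3 (1.29 log units; beyond the scatter) as well, so the large drop seen earlier is not confined to fluoro. Going by these compounds, the true size of that step stays unknown because compound 1 stands at a limit and not at a number: the limit of > 80000 nM in this assay, at which 1 of the 3 values shown sits. On these data alone, whether a halogen is needed here remains open, since an amine, a nitrile or a methoxy group at this place would answer that.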